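Aryl in Place of Ethyl on the Ring Nitrogen

The source may report more compounds than this note shows. Statements on the series, on what has been measured and on what is new or still open speak of the compounds shown alone.

Two carbamates sharing one core have so far been measured in an assay on isolated protein for inhibition of Fatty-acid amide hydrolase 1 (Homo sapiens), read by fluorescence, with a stated time of 30 min; a lower number here means a stronger inhibitor, a higher number a weaker inhibitor. Compound 1 `CCOC(=O)c1cc(-c2cccc(OC(=O)NC3CCCCC3)c2)n(CC)n1` gives 101 nM. Compound 2 `CCOC(=O)c1cc(-c2ccc(OC(=O)NC3CCCCC3)cc2)n(CC)n1` gives 214 nM, which is the higher of the two numbers, and its gap to compound 1 is a little beyond the usual scatter of this assay, so compound 2 counts as the weaker inhibitor of the pair.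

Compound 3 `CCOC(=O)c1cc(-c2ccc(OC(=O)NC3CCCCC3)cc2)n(-c2ccc(Cl)cc2)n1` has not yet been measured. It differs from compound 2 in a single place: 4-chlorophenyl in place of ethyl on an aromatic nitrogen. Going by the values given here, no measured pair in this set shows what such an exchange does, so any expectation rests on compound 2 alone and on the fact that the change leaves the carbamate and the ethoxycarbonyl group untouched. The step from compound 2 to compound 3 is expected to be modest, a 1.8-fold lower number from compound 2 to compound 3 (0.25 log units; within the scatter), with a lower number somewhat more likely than a higher one, though a result within the scatter would not surprise. Compound 3 is therefore estimated at 120 nM, with a plausible range from 30 nM to 500 nM.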

Compound 3, half-maximal inhibitory concentration: 281 nM
Estimate against measurement, compound 3: 2.3-fold (0.37 log units) below; measured number inside the range.
By their numbers in this assay, from the lowest: compound 1; then compounds 2 and 3 (each within the scatter of the next).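

In this assay, putting 4-chlorophenyl in place of ethyl on the aromatic nitrogen gives a 1.3-fold higher number from compound 2 to compound 3 (0.12 log units; within the scatter) and so leaves compound 2 and compound 3 impossible to tell apart. Going by these compounds alone, the earlier compounds both carried ethyl at this position, so this is the first sign that it can hold a much larger group: 7 heavy atoms, including a six-membered aromatic ring, where ethyl has only 2. The inhibition read in this assay stays within the usual scatter despite that exchange, although this rests on a single pair of compounds and cannot yet be called a general rule for the position.

Still open, going by these compounds, is whether plain phenyl without the chlorine, a longer chain such as butyl, or a group carrying an amine or a carboxylic acid would fit this position equally well, and whether 4-chlorophenyl would give a similar result on the core of compound 1. Nothing shown here explains why compound 2 and compound 3 cannot be told apart.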